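This account rests on a few compounds, and the source may have more. Where it says the series, first, only, none or still open, it means among the compounds named here.

Measured compounds and their numbers:

compound 1 `Nc1nc(N/N=C/c2ccc(OCc3ccc(F)cc3)cc2)nc2c1ncn2[C@@H]1O[C@H](CO)[C@@H](O)[C@H]1O` — 70 nM
compound 2 `CCOc1cc(/C=N/Nc2nc(N)c3ncn([C@@H]4O[C@H](CO)[C@@H](O)[C@H]4O)c3n2)ccc1O` — 6940 nM
compound 3 `CN(C)c1ccc(/C=N/Nc2nc(N)c3ncn([C@@H]4O[C@H](CO)[C@@H](O)[C@H]4O)c3n2)cc1` — reported only as a limit, > 10000 nM

In an assay on CHO-K1 cells for displacement of a labelled ligand from adenosine receptor A1 (Homo sapiens), read by scintillation counting, with a stated time of 60 min (on this read-out lower numbers stand for stronger inhibition and higher numbers for weaker inhibition), compound 1 gives the lower of the two numbers shown, and compound 2 sits far higher with 6940 nM. For compound 3 this assay gives no number but a limit, > 10000 nM. Compound 4 `N#Cc1ccc(/C=N/Nc2nc(N)c3ncn([C@@H]4O[C@H](CO)[C@@H](O)[C@H]4O)c3n2)cc1` is the next variation on the shared core: cyano in place of (4-fluorobenzyl)oxy on an aromatic carbon.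

Among the compounds with values here, only one measured step swaps out the same (4-fluorobenzyl)oxy group: an at least 140-fold higher number from compound 1 to compound 3 (2.15 log units; beyond the scatter), where dimethylamino takes its place and the number runs past the assay ceiling, (the limit of > 10000 nM in this assay, at which 1 of the 3 values shown sits). The step of an at least 1.4-fold higher number from compound 2 to compound 3 (0.15 log units; that floor lies within the scatter) adds little, since both compounds carry small groups and both sit high. Nothing measured here carries a cyano group, so the size of the change is uncertain, but the move away from the large (4-fluorobenzyl)oxy is expected to cost a lot. Compound 4 is therefore expected to show a 71-fold higher number from compound 1 to compound 4 (1.85 log units; beyond the scatter), with an estimated 5000 nM lying somewhere from 1000 nM to 20000 nM.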

Compound 4, inhibition constant: 4.1 nM
For compound 4 the middle estimate is 1200-fold (3.09 log units) above the measured one, and the stated range ends above it.
By their numbers in this assay, from the lowest: compound 4; then compound 1; then compound 2. At a limit, above all of these: compound 3.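

At this position, on an aromatic carbon para to a large group, the large (4-fluorobenzyl)oxy group is not needed for a low number in this assay: cyano gives a 17-fold lower number from compound 1 to compound 4 (1.23 log units; beyond the scatter). Small groups no longer go with high numbers, as they did in compounds 2 and 3, and compound 4 goes against that earlier pattern, with a 1700-fold lower number from compound 2 to compound 4 (3.23 log units; beyond the scatter). With cyano in place of dimethylamino there is an at least 2400-fold lower number from compound 3 to compound 4 (3.38 log units; beyond the scatter), and this is only a floor, as compound 3 is reported as a limit: the limit of > 10000 nM in this assay, at which 1 of the 4 values shown sits.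

On these data alone, whether the low number is particular to cyano remains open, since a carboxylic acid, a primary amide or a chlorine atom on the same carbon could fall near compound 4 or far from it. Compound 2 also differs from compound 4 by both its ethoxy and its hydroxy group, so the separate contribution of each remains unresolved.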